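From trifluoromethylbenzyl to dichlorobenzyl in the urea series

The compounds below may be only part of what the source reports. "The series", "measured", "known", "first", "only" and "open" are said of these compounds alone.

Among the measured compounds shown here, compound 3 `Cc1ccc(NC(=O)NC(=O)c2ccc(OCc3cccc(C(F)(F)F)c3)cc2)cc1-c1nc2ccccc2[nH]1` gives 3520 nM in a functional assay on HT-29 cells (Homo sapiens) for inhibition, read by MTT assay, with a stated time of 48 h (a lower number here means a stronger inhibitor, a higher number a weaker inhibitor), the lowest of the three numbers measured so far. Compound 2 `Cc1ccc(NC(=S)NC(=O)c2ccc(OCc3ccc(Cl)c(Cl)c3)cc2)cc1-c1nc2ccccc2[nH]1` gives 6270 nM, which lies within the scatter of compound 3, while compound 1 `Cc1ccc(NC(=S)NC(=O)c2ccc(OCc3ccccc3)cc2)cc1-c1nc2ccccc2[nH]1` gives 28800 nM, well beyond it. Compound 4 `Cc1ccc(NC(=O)NC(=O)c2ccc(OCc3ccc(Cl)c(Cl)c3)cc2)cc1-c1nc2ccccc2[nH]1` differs from compound 3 by 3,4-dichlorophenyl in place of 3-(trifluoromethyl)phenyl on a saturated chain carbon bound to an oxygen on an aromatic ring. For the measured compounds named here, no measured step makes this exact exchange; the nearest is a 4.6-fold lower number from compound 1 to compound 2 (0.66 log units; beyond the scatter), which shows the entering group giving a lower number in a different series, though starting from plain phenyl rather than from the trifluoromethyl-bearing ring. The closeness of compound 2 to compound 3 suggests little change here. Compound 4 is therefore expected to show a step of a 1.2-fold lower number from compound 3 to compound 4 (0.07 log units; within the scatter), within the scatter. Compound 4 is estimated at 3000 nM, between 1200 nM and 8000 nM.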

Compound 4, half-maximal inhibitory concentration: 1030 nM
Beside the measured number, compound 4's estimate is 2.9-fold (0.46 log units) above it, and the stated range ends above it.
By their numbers in this assay, from the lowest: compound 4; then compounds 3 and 2 (each within the scatter of the next); then compound 1.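

In this assay, among the compounds shown here, the exchange gives a 3.4-fold lower number from compound 3 to compound 4 (0.53 log units; beyond the scatter), so at this place the two substituted rings are not interchangeable, a direct comparison the earlier compounds did not offer. The 3,4-dichlorophenyl group thus gives a lower number against 3-(trifluoromethyl)phenyl as well as against plain phenyl, as in a 4.6-fold lower number from compound 1 to compound 2 (0.66 log units; beyond the scatter) within the other series. Nothing measured here explains why the numbers differ. Still open, as far as these compounds go, is how a benzyl ring carrying an amine or a carboxylic acid would compare, and whether a longer chain in place of the saturated chain carbon would keep this gain.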